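Swapping the pyridyl ether: what to expect for compound 4

The source may report more compounds than this note shows. Statements on the series, on what has been measured and on what is new or still open speak of the compounds shown alone.

Three compounds share one core and differ in the pyridyl group placed on an oxygen on an aromatic ring. In a physicochemical assay for solubility, read by HPLC, measured as thermodynamic solubility, with a stated time of 4 h, at pH 6.8 (a higher number here means a more soluble compound, a lower number a less soluble compound), compound 1 `Cn1c(COc2cccc(C(=O)O)c2)nc2ccc(Oc3cccc(Cl)n3)cc21` gives 7.7 ug/mL, compound 2 `Cn1c(COc2cccc(C(=O)O)c2)nc2ccc(Oc3ncccc3F)cc21` gives 7.1 ug/mL, and compound 3 `Cc1cnc(Oc2ccc3nc(COc4cccc(C(=O)O)c4)n(C)c3c2)c(F)c1` gives 9.2 ug/mL. On these numbers compound 3 sits nearest compound 1 and furthest from compound 2, with a 1.2-fold higher number from compound 1 to compound 3 (0.08 log units; within the scatter) and a 1.3-fold higher number from compound 2 to compound 3 (0.11 log units; within the scatter), both within the scatter. Compound 4 `Cc1cc(Cl)cnc1Oc1ccc2nc(COc3cccc(C(=O)O)c3)n(C)c2c1` carries the change (5-chloro-3-methylpyridin-2-yl in place of 3-fluoro-5-methylpyridin-2-yl on an oxygen on an aromatic ring). The earlier pyridyl swaps, a 1.1-fold lower number from compound 1 to compound 2 (0.04 log units; within the scatter) and a 1.2-fold higher number from compound 1 to compound 3 (0.08 log units; within the scatter), shifted this assay by nothing beyond the scatter, so no step beyond the scatter is expected here either. Compound 4 is therefore expected to give about 8 ug/mL in this assay, between 4 ug/mL and 16 ug/mL. The expected step, a 1.2-fold lower number from compound 3 to compound 4 (0.06 log units; within the scatter), is thus estimated to remain within the scatter.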

Compound 4, solubility: 3.9 ug/mL
Compound 4: middle estimate off by 2.1-fold (0.31 log units), on the high side; measured number below the stated range.
By their numbers in this assay, from the lowest: compounds 4, 2, 1 and 3 (each within the scatter of the next, the first and the last beyond it).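

In this assay, going by these compounds alone, this is the first pyridyl swap on the oxygen to step beyond the scatter (a 2.4-fold lower number from compound 3 to compound 4 (0.37 log units; beyond the scatter)), with 5-chloro-3-methylpyridin-2-yl in place of 3-fluoro-5-methylpyridin-2-yl. Against the other two compounds, the same group stays within the scatter (a 1.8-fold lower number from compound 2 to compound 4 (0.26 log units; within the scatter); a 2.0-fold lower number from compound 1 to compound 4 (0.30 log units; within the scatter)), so only the gap to compound 3 is resolved. Nothing measured here accounts for that step.

The swap changes the halogen and the place of the methyl together, and the compounds shown do not separate the two. As far as these compounds go, whether an amine or a methoxy group on this pyridyl ring would shift the number also stays open.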